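Amide substituent and solubility in the shared core

A few compounds are considered here, and "the series" means these few. Any claim that something is new, unique, unknown or untested is made for them only; others in the source may bear on it.

Of the compounds shown here, three have been measured in a physicochemical assay for solubility, read by HPLC, in phosphate buffer, with a stated time of 4 h, at pH 7.4; a higher number here means a more soluble compound, a lower number a less soluble compound. Compound 1 `Cc1cc(/C=C/C#N)cc(C)c1Oc1cc(Nc2ccc(C#N)cc2)c(N)cc1C(=O)OCCC#N` gives 0.36 ug/mL. Compound 2 `Cc1cc(/C=C/C#N)cc(C)c1Oc1cc(Nc2ccc(C#N)cc2)c(N)cc1C(=O)NCCC(F)F` gives 6.59 ug/mL. Compound 3 `Cc1cc(/C=C/C#N)cc(C)c1Oc1cc(Nc2ccc(C#N)cc2)c(N)cc1C(N)=O` gives 0.63 ug/mL. Compound 2 stands highest of the three: the step of an 18-fold higher number from compound 1 to compound 2 (1.26 log units; beyond the scatter) and the step of a 10-fold lower number from compound 2 to compound 3 (1.02 log units; beyond the scatter) both lie beyond the scatter, whereas a 1.8-fold higher number from compound 1 to compound 3 (0.24 log units; within the scatter) does not.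

Compound 4 `CNC(=O)c1cc(N)c(Nc2ccc(C#N)cc2)cc1Oc1c(C)cc(/C=C/C#N)cc1C` is next in line. It differs from compound 2 by hydrogen in place of 2,2-difluoroethyl on a saturated chain carbon bound to an amide-type nitrogen.

The step that bears most directly on this change is a 10-fold lower number from compound 2 to compound 3 (1.02 log units; beyond the scatter), in which the whole chain on the amide-type nitrogen is replaced by hydrogen. Compound 4 keeps a methyl on that nitrogen, so the change is smaller than that one, and a drop of intermediate size in this assay is expected, toward but not down to compound 3. The expected step is a 4.4-fold lower number from compound 2 to compound 4 (0.64 log units; beyond the scatter). Compound 4 is estimated at 1.5 ug/mL, with a range from 0.5 ug/mL to 4.5 ug/mL.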

Compound 4, solubility: 8.28 ug/mL
Beside the measured number, compound 4's estimate is 5.5-fold (0.74 log units) below it; the measured number lies above the stated range.
By their numbers in this assay, from the lowest: compounds 1 and 3 (each within the scatter of the next); then compounds 2 and 4 (each within the scatter of the next).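

In this assay the length of the chain on the amide-type nitrogen does not separate the two amides: a 1.3-fold higher number from compound 2 to compound 4 (0.10 log units; within the scatter) shows that methyl serves as well as 3,3-difluoropropyl here, so the 2,2-difluoroethyl part can leave without a measurable loss. The large step lies instead at the first carbon on that nitrogen, with a 13-fold higher number from compound 3 to compound 4 (1.12 log units; beyond the scatter) for methyl in place of hydrogen, and methylamino likewise stands well clear of 2-cyanoethoxy on the carbonyl carbon, with a 23-fold higher number from compound 1 to compound 4 (1.36 log units; beyond the scatter) as that step. Nothing measured here accounts for the size of the methyl step.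

Going by these compounds, whether an unfluorinated propyl chain or a second methyl on the amide-type nitrogen gives a number like these remains open. So does the effect of a chain ending in an amine or a carboxylic acid.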